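Nitro in Place of Trifluoromethyl on Two Cores

The source may hold more compounds than are shown below. What is called first, only, known or untested is meant among the compounds shown, and "the series" means these compounds.

Compound 1 `CCOC(=O)N1CCC(=NNC(=O)c2ccc(C(F)(F)F)cc2)CC1` carries a trifluoromethyl group on its aromatic ring. In a functional assay on A549 cells (Homo sapiens) for cytotoxicity, read by MTT assay, with a stated time of 24 h (on this read-out higher numbers stand for weaker inhibition and lower numbers for stronger inhibition), compound 1 gives 37100000 nM. Compound 2 `CCOC(=O)N1CCC(=NNC(=O)c2ccc([N+](=O)[O-])cc2)CC1` differs from compound 1 by nitro in place of trifluoromethyl on an aromatic carbon. In this assay compound 2 gives only a limit, > 400000 nM. The step that the limit leaves unreadable from compound 1 to compound 2 therefore cannot be sized, which rests on (the limit of > 400000 nM in this assay, at which 2 of the 3 values shown sit).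

Compound 3 `O=C(NN=C1CC(c2ccccc2)NC(c2ccccc2)C1)c1ccc(C(F)(F)F)cc1` carries the same trifluoromethyl-bearing ring on another core; the difference between the two cores is not broken down here. In this assay compound 3 gives only a limit, > 400000 nM.

Compound 4 `O=C(NN=C1CC(c2ccccc2)NC(c2ccccc2)C1)c1ccc([N+](=O)[O-])cc1` has not yet been measured in this assay. It differs from compound 3 by nitro in place of trifluoromethyl on an aromatic carbon, which is the same change as that between compound 1 and compound 2, made at the same kind of place.

Within the data shown here, what can be expected of compound 4 rests on two things: compound 3 already gives no number but a limit in this assay, and the one measured instance of this change, the step that the limit leaves unreadable from compound 1 to compound 2, is itself left unreadable by the limit. Neither gives any sign that the change brings a compound back under the limit. The step from compound 3 to compound 4 is therefore expected to be a step that the limit leaves unreadable from compound 3 to compound 4, essentially no change at the limit. Compound 4 is accordingly estimated at 1000000 nM in this assay, most likely reported again as a limit, within an expected range from 400000 nM to 50000000 nM.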

Compound 4, half-maximal inhibitory concentration: > 400000 nM
Compound 4: no number, only a limit (the forecaster's own chance of this, stated with the estimate: 85%); the middle value does not contradict the limit.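

Among these compounds, compound 4, like compound 3, gives only a limit in this assay, so the step between them cannot be read, and no new step emerges: (the limit of > 400000 nM in this assay, at which 3 of the 4 values shown sit).

The compounds shown leave open how far nitro in place of trifluoromethyl shifts this read-out on either core, and how the two cores compare, with compound 1 the only one of the four to give a number.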